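A Pyridine Swap on a Cytotoxic Amide Scaffold

This account rests on a few compounds, and the source may have more. Where it says the series, first, only, none or still open, it means among the compounds named here.

Compound 1 `COc1cccc(CNC(=O)c2nc(Br)c3cccnc3c2N[C@H]2CC[C@H](N)CC2)c1` was tested in a functional assay on MDA-MB-435 cells (Homo sapiens) for cytotoxicity, read by MTT assay, with a stated time of 72 h (on this read-out higher numbers stand for weaker inhibition and lower numbers for stronger inhibition), where compound 1 gives 7000 nM. Going by the values given here, this is the only actual number in the set, because the other entry is a limit, (the limit of > 20000 nM in this assay, at which 1 of the 2 values shown sits). Compound 2 `C[C@@H](Nc1c(C(=O)NCc2ccc(F)cc2)nc(Br)c2cccnc12)c1ccccc1` in this assay reaches only > 20000 nM, which is a limit of the assay rather than a number. Compound 3 `N[C@H]1CC[C@H](Nc2c(C(=O)NCc3ccccn3)nc(Br)c3cccnc23)CC1` differs from compound 1 by pyridin-2-yl in place of 3-methoxyphenyl on a saturated chain carbon bound to an amide-type nitrogen. Among the compounds with values here, no measured step of this kind exists here, so the expected change from compound 1 to compound 3 is small, a 1.1-fold higher number from compound 1 to compound 3 (0.06 log units; within the scatter), with no clear direction beyond the usual scatter. Compound 3 is thus expected to give about 8000 nM, within 2500 nM to 25000 nM.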

Compound 3, half-maximal inhibitory concentration: 4000 nM
Compound 3: middle estimate off by 2.0-fold (0.30 log units), on the high side; low and high end bracket the measured number.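

In this assay, pyridin-2-yl in place of 3-methoxyphenyl on a saturated chain carbon bound to an amide-type nitrogen gives a 1.8-fold lower number from compound 1 to compound 3 (0.24 log units; within the scatter) and so leaves the two compounds indistinguishable. This place therefore keeps its cytotoxic reading when a carbon-only ring bearing methoxy gives way to a ring containing nitrogen. Nothing measured here explains why the two groups read alike. Still open, on these data alone, is whether the ring nitrogen or the missing methoxy matters, which an unsubstituted phenyl could help separate. Also open, as far as these compounds go, is how this place responds to a carboxylic acid, an amine or a longer chain.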